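Methyl to Trifluoromethyl: Expecting Compound 4

A few compounds are considered here, and "the series" means these few. Any claim that something is new, unique, unknown or untested is made for them only; others in the source may bear on it.

Of the compounds shown here, three sharing one core have been measured in a functional assay for activation of Alpha-1A adrenergic receptor (Homo sapiens), read by calcium flux; on this read-out higher numbers stand for an effect only at larger amounts of compound and lower numbers for an effect already at smaller amounts. Compound 1 `c1ccc(-c2ccccc2NCC2=NCCN2)nc1` gives 6.76 nM, compound 2 `c1ccc(-c2cnccn2)c(NCC2=NCCN2)c1` gives 4.57 nM, and compound 3 `Cc1cccnc1-c1ccccc1NCC1=NCCN1` gives 24.6 nM. Compound 3 thus stands highest of the three numbers: there is a 3.6-fold higher number from compound 1 to compound 3 (0.56 log units; beyond the scatter), whereas there is only a 1.5-fold lower number from compound 1 to compound 2 (0.17 log units; within the scatter), so compound 1 and compound 2 cannot be ordered against each other, while compound 3 lies beyond the scatter from both.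

Compound 4 `FC(F)(F)c1cccnc1-c1ccccc1NCC1=NCCN1` differs from compound 3 in one place: trifluoromethyl in place of methyl on an aromatic carbon. The group sits on an aromatic carbon of a six-membered aromatic ring with 1 nitrogen, ortho to a large group, two atoms from the ring nitrogen. Going by the values given here, only one measured step touches this place, namely a 3.6-fold higher number from compound 1 to compound 3 (0.56 log units; beyond the scatter), where hydrogen gave way to methyl. The step from compound 1 to compound 2 concerns another part of the molecule and does not inform this change. Among the compounds with values here, no measured compound carries a trifluoromethyl, so its effect here is unknown. Because a 3.6-fold higher number from compound 1 to compound 3 (0.56 log units; beyond the scatter) was modest and upward, a further modest rise is expected, a 2.4-fold higher number from compound 3 to compound 4 (0.39 log units; beyond the scatter). Compound 4 is therefore estimated at 60 nM, with a range from 15 nM to 250 nM.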

Compound 4, half-maximal effective concentration: 676 nM
Estimate against measurement, compound 4: 11-fold (1.05 log units) below, outside the stated range (above it).
By their numbers in this assay, from the lowest: compounds 2 and 1 (each within the scatter of the next); then compound 3; then compound 4.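

In this assay, going by these compounds alone, this aromatic carbon, ortho to a large group and two atoms from the ring nitrogen, turns out to respond far more strongly to substitution than the earlier compounds showed: trifluoromethyl in place of methyl gives a 27-fold higher number from compound 3 to compound 4 (1.44 log units; beyond the scatter), a large step, whereas hydrogen to methyl gave only the modest 3.6-fold higher number from compound 1 to compound 3 (0.56 log units; beyond the scatter). Taken directly against hydrogen, trifluoromethyl gives a 100-fold higher number from compound 1 to compound 4 (2.00 log units; beyond the scatter), so the three groups on this carbon fall in one upward order, hydrogen, then methyl, then trifluoromethyl, with most of the total rise coming in the last step. Nothing available here bears on why the exchange of methyl for trifluoromethyl has so large an effect.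

From the compounds shown here alone, whether a chlorine, a methoxy group or a nitrile on this same carbon would fall nearer compound 3 or nearer compound 4 remains open, so three groups cannot yet say what the order follows. Also open, going by these compounds, is whether trifluoromethyl would give a step of similar size on the pyrazin-2-yl ring of compound 2.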